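The compounds below may be only part of what the source reports. "The series", "measured", "known", "first", "only" and "open" are said of these compounds alone.

Measured so far, in a functional assay on A549 cells (Homo sapiens) for inhibition, read by MTT assay, with a stated time of 48 h; on this read-out higher numbers stand for weaker inhibition and lower numbers for stronger inhibition:
- compound 1 `COc1cc(/C=N/Nc2nc(-c3ccc(Br)cc3)cs2)cc(Br)c1OC` gives 52300 nM
- compound 2 `COc1cc(/C=N/Nc2nc(-c3ccc(C(F)(F)F)cc3)cs2)c(Br)c(Br)c1OC` gives 17600 nM
- compound 3 `COc1cc(/C=N/Nc2nc(-c3ccccc3)cs2)c(Br)c(Br)c1OC` gives 15300 nM

Compound 2 stands second highest of the three numbers. Its nearest neighbour is compound 3, and the step of a 1.2-fold lower number from compound 2 to compound 3 (0.06 log units; within the scatter) lies within the scatter, so the two are not distinguished here. For the measured compounds named here, its furthest neighbour is compound 1, whose number is higher than that of compound 2 by a margin beyond the scatter; compound 1 and compound 2 differ in two places at once, so no single step is counted between them.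

Compound 4 `COc1cc(/C=N/Nc2nc(-c3ccc(C(F)(F)F)cc3)cs2)cc(Br)c1OC` is not yet measured. It differs from compound 2 by hydrogen in place of bromo on an aromatic carbon.

Which measured steps bear on it: the only single-place step, from compound 2 to compound 3, sits on the other aromatic ring and concerns trifluoromethyl, not bromo, so it says little about this change. The pair compound 1 and compound 2 shows that the compound carrying one bromo on this ring gives the higher number. That pair also differs at the trifluoromethyl site, so the share of the bromo alone cannot be separated.

In this assay compound 4 is therefore expected to move toward a higher number, by about a 2.0-fold higher number from compound 2 to compound 4 (0.30 log units; within the scatter), with wide uncertainty. The estimate for compound 4 is 35000 nM, range 15000 nM to 80000 nM.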

Compound 4, half-maximal inhibitory concentration: 18300 nM
For compound 4 the middle estimate is 1.9-fold (0.28 log units) above the measured one; the range from low to high includes it.
By their numbers in this assay, from the lowest: compounds 3, 2 and 4 (each within the scatter of the next); then compound 1.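

In this assay, the step of a 1.0-fold higher number from compound 2 to compound 4 (0.02 log units; within the scatter) shows that hydrogen and the bromo ortho to a bromo group are not distinguished at this position, at least with trifluoromethyl on the other aromatic ring. The gap between compound 1 and compound 2 could not be divided between its two sites earlier, but the single-place step a 2.9-fold lower number from compound 1 to compound 4 (0.46 log units; beyond the scatter) now shows a modest change beyond the scatter on trifluoromethyl in place of bromo, with the core of compound 1 otherwise unchanged. No measurement shown accounts for the size of either step.

Still open, on these data alone, is whether this position tolerates other replacements for the bromo, such as an amine or a carboxylic acid, since only bromo and hydrogen appear here and the flat step a 1.2-fold lower number from compound 2 to compound 3 (0.06 log units; within the scatter) concerns the other ring. Also open, as far as these compounds go, is whether hydrogen in place of this bromo would stay within the scatter with bromo rather than trifluoromethyl on the other ring, and whether hydrogen on that ring would match trifluoromethyl or bromo in the single-bromo series.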